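Carbamate ester chain variation in an angiotensin receptor series

The source may hold more compounds than are shown below. What is called first, only, known or untested is meant among the compounds shown, and "the series" means these compounds.

Measured compounds:
Compound 1, `CC(C)Cc1cc(-c2cccc(Cn3ccnc3)c2)c(S(=O)(=O)NC(=O)OC(C)C)s1`: 160 nM
Compound 2, `CC(C)COC(=O)NS(=O)(=O)c1sc(CC(C)C)cc1-c1cccc(Cn2ccnc2)c1`: 130 nM
Compound 3, `CC(C)CCOC(=O)NS(=O)(=O)c1sc(CC(C)C)cc1-c1cccc(Cn2ccnc2)c1`: 230 nM

All three share one core and differ only in the alkyl group on the oxygen next to the carbonyl group, tested in an assay on HEK293 cells for displacement of a labelled ligand from Type-2 angiotensin II receptor (Homo sapiens), read by scintillation counting, with a stated time of 240 min; on this read-out higher numbers stand for weaker inhibition and lower numbers for stronger inhibition. Compound 3 carries the isopentyl chain, and its number sits at the end of the set where the other two do not: the step of a 1.4-fold higher number from compound 1 to compound 3 (0.16 log units; within the scatter) and the step of a 1.8-fold higher number from compound 2 to compound 3 (0.25 log units; within the scatter) both lie within the scatter, so the three cannot be told apart with confidence. Likewise a 1.2-fold lower number from compound 1 to compound 2 (0.09 log units; within the scatter) shows no real movement between isopropyl and isobutyl.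

Compound 4, `CC(C)Cc1cc(-c2cccc(Cn3ccnc3)c2)c(S(=O)(=O)NC(=O)OCC2CC2)s1`, is the next member. Its change from compound 3 is cyclopropyl in place of isobutyl on a saturated chain carbon bound to an oxygen next to a carbonyl group. Going by the values given here, since every chain swap at this position so far, isopropyl to isobutyl to isopentyl, stayed within the scatter, a move to cyclopropylmethyl is expected to do the same, with no direction favoured beyond noise in this assay.

For compound 4 the expected result is therefore 170 nM, within 75 nM to 380 nM, which corresponds to the estimated step of a 1.4-fold lower number from compound 3 to compound 4 (0.13 log units; within the scatter).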

Compound 4, inhibition constant: 140 nM
Estimate against measurement, compound 4: 1.2-fold (0.08 log units) above, within the range that was stated.
By their numbers in this assay, from the lowest: compounds 2, 4, 1 and 3 (each within the scatter of the next).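

Adding a ring to this chain for the first time leaves the number in this assay unresolved from those of the open chains: cyclopropylmethyl gives a step from each of them (a 1.6-fold lower number from compound 3 to compound 4 (0.22 log units; within the scatter); a 1.1-fold higher number from compound 2 to compound 4 (0.03 log units; within the scatter); a 1.1-fold lower number from compound 1 to compound 4 (0.06 log units; within the scatter)), and all three steps lie within the scatter. The earlier compounds shown here showed only that branched open chains of different lengths could not be told apart, whereas compound 4 extends this to a group with a three-membered non-aromatic ring of carbon only, so isopropyl, isobutyl, isopentyl and cyclopropylmethyl are four groups on this oxygen that this assay cannot separate, with no compound among them going against that. Nothing available here offers an explanation for why the number stays so flat across these changes.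

From the compounds shown here alone, all four groups are small and made of carbon alone, so it remains open what a chain carrying an amine or a carboxylic acid would do at this place. It is equally unknown whether a much longer chain such as octyl, or a larger ring such as benzyl or cyclohexylmethyl, would move the number beyond the scatter.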